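Swapping the Amide Aryl Group in Compound 1

This account rests on a few compounds, and the source may have more. Where it says the series, first, only, none or still open, it means among the compounds named here.

Going by the values given here, compound 1 `CCN1CCN(c2cc(C)c3cc(NC(=O)c4cccc(Cl)c4)ccc3n2)CC1` stands at the lower of the two numbers measured so far in a functional assay on MCF7 cells (Homo sapiens) for antiproliferative activity, read by MTT assay, with a stated time of 72 h (on this read-out lower numbers stand for stronger inhibition and higher numbers for weaker inhibition), where compound 1 gives 3820 nM. Compound 2 `Cc1cc(N2CCCCC2)nc2ccc(NC(=O)c3ccc(Cl)c(Cl)c3)cc12` gives 31100 nM in this assay, a higher number that lies beyond the usual scatter. Compound 3 `CCN1CCN(c2cc(C)c3cc(NC(=O)c4ccc(OC)cc4)ccc3n2)CC1` has not yet been measured. It differs from compound 1 in one place: 4-methoxyphenyl in place of 3-chlorophenyl on a carbonyl carbon. Among the compounds with values here, no measured pair in this set carries that same change, so its size cannot be read from the numbers at hand; the two measured compounds differ in several places at once and do not isolate the amide aryl group. A modest step, most likely toward a higher number though possibly none beyond the scatter, is expected for a 1.6-fold higher number from compound 1 to compound 3 (0.20 log units; within the scatter). Compound 3 is estimated to give 6000 nM in this assay, with a range from 2000 nM to 20000 nM.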

Compound 3, half-maximal inhibitory concentration: 7690 nM
Compound 3: middle estimate off by 1.3-fold (0.11 log units), on the low side, within the range that was stated.
By their numbers in this assay, from the lowest: compounds 1 and 3 (each within the scatter of the next); then compound 2.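

Going by these compounds alone, compound 1 and compound 3 form the first pair here that differs in one place, so the amide aryl group can now be read on its own in this assay as a single change. Putting 4-methoxyphenyl in place of 3-chlorophenyl on a carbonyl carbon gives a 2.0-fold higher number from compound 1 to compound 3 (0.30 log units; within the scatter) and so does not separate the two groups on this read-out. Nothing on hand explains how either group acts at this position.

The step cannot be divided between the exchange of chlorine for methoxy and the different placing of the two groups, which a 4-chlorophenyl or 3-methoxyphenyl group would address. On these data alone, it also remains open whether an amine or a carboxylic acid on this aryl ring would give a step beyond the scatter.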